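The compounds below may be only part of what the source reports. "The series", "measured", "known", "first", "only" and "open" are said of these compounds alone.

Measured compounds and their values:

- Compound 1 `CC(C)c1noc(-c2ccc(C3=NCCN3)cc2)n1` gives 22500 nM in an assay for inhibition of Amine oxidase [flavin-containing] A (Homo sapiens), read by fluorescence and spectrophotometry, using microsomes, with stated times of 30 min and 20 min; on this read-out lower numbers stand for stronger inhibition and higher numbers for weaker inhibition.
- Compound 2 `c1ccc(OCc2noc(-c3ccc(C4=NCCN4)cc3)n2)cc1` gives > 100000 nM in this assay, which is a limit of the assay and not a number.
- Compound 3 `c1csc(-c2noc(-c3ccc(C4=NCCN4)cc3)n2)c1` gives 1570 nM in this assay.

All three share one core and differ only in the group on one aromatic carbon of it. Compound 3 gives the lowest of the two numbers: the step of a 14-fold lower number from compound 1 to compound 3 (1.16 log units; beyond the scatter) and the step of an at least 63-fold lower number from compound 2 to compound 3 (1.80 log units; beyond the scatter) both lie well beyond the scatter, while the step of an at least 4.4-fold higher number from compound 1 to compound 2 (0.64 log units; beyond the scatter) runs the other way.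

Compound 4 `Clc1cccc(-c2noc(-c3ccc(C4=NCCN4)cc3)n2)c1` is not yet measured. It differs from compound 3 in one place: 3-chlorophenyl in place of thiophen-2-yl on an aromatic carbon. The two steps that bear on this are those ending at compound 3, a 14-fold lower number from compound 1 to compound 3 (1.16 log units; beyond the scatter) and an at least 63-fold lower number from compound 2 to compound 3 (1.80 log units; beyond the scatter), in which an aromatic ring on that carbon went with a far lower number than an isopropyl or a phenoxymethyl group. Compound 4 keeps an aromatic ring there, so a step no larger than the scatter is expected in this assay, perhaps a slightly higher number, which would mean a 1.6-fold higher number from compound 3 to compound 4 (0.20 log units; within the scatter). The value of compound 4 is therefore expected to be about 2500 nM, between 800 nM and 8000 nM.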

Compound 4, half-maximal inhibitory concentration: 5470 nM
For compound 4 the middle estimate is 2.2-fold (0.34 log units) below the measured one; the range from low to high includes it.
By their numbers in this assay, from the lowest: compound 3; then compound 4; then compound 1. At a limit, above all of these: compound 2.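

In this assay, the identity of the aromatic ring on this carbon matters, not only its presence: a 3.5-fold higher number from compound 3 to compound 4 (0.54 log units; beyond the scatter), so the larger 3-chlorophenyl ring does not match thiophen-2-yl. Even so, compound 4 keeps a clear edge over the non-ring isopropyl group, with a 4.1-fold lower number from compound 1 to compound 4 (0.61 log units; beyond the scatter), so compound 1 and compound 3 are not alone in setting the trend: a second, different aromatic ring also goes with a lower number. Compound 2 stands at a limit and not a number, so an at least 18-fold lower number from compound 2 to compound 4 (1.26 log units; beyond the scatter) gives only a minimum size for that step: the limit of > 100000 nM in this assay, at which 1 of the 4 values shown sits.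

With only two rings shown, the effect of the ring's size and that of its chlorine cannot be told apart. A plain phenyl ring would separate them, and a phenyl ring carrying a methoxy group or an amine would show how far this position tolerates other substituents.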